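Series notes: heptyl replaced by phenyl on the core

The compounds below may be only part of what the source reports. "The series", "measured", "known", "first", "only" and "open" are said of these compounds alone.

Measured in a functional assay on A2780 cells (Homo sapiens) for antiproliferative activity, read by sulforhodamine B assay, with a stated time of 48 h; a higher number here means a weaker inhibitor of growth, a lower number a stronger inhibitor of growth:
- compound 1 `CCCCCCC[C@H]1C[C@H](Cl)CCN1S(=O)(=O)c1ccc(C)cc1`: > 100000 nM, a limit of the assay rather than a number
- compound 2 `Cc1ccc(S(=O)(=O)N2CC[C@@H](Cl)C[C@@H]2C2CCCCC2)cc1`: 72000 nM

Compound 1 stands only at the limit of > 100000 nM in this assay, at which 1 of the 2 values shown sits, so its true value is not pinned down. For the measured compounds named here, the single measured step that touches the same position is an at least 1.3-fold lower number from compound 1 to compound 2 (0.14 log units; that floor lies within the scatter); it reads as no change beyond the scatter, and with one end a limit it cannot be sized. Compound 3 `Cc1ccc(S(=O)(=O)N2CC[C@@H](Cl)C[C@@H]2c2ccccc2)cc1` differs from compound 1 by phenyl in place of heptyl on a saturated ring carbon. Both measured compounds show that the shared core with a seven-carbon chain or a saturated six-membered ring at this carbon is a weak inhibitor of growth, and phenyl, another six-membered ring at the same carbon, gives no grounds to expect a step larger than the scatter in this assay. Compound 3 is therefore expected near 60000 nM, between 20000 nM and 150000 nM. The expected step is an at least 1.6-fold lower number from compound 1 to compound 3 (0.22 log units; that floor lies within the scatter).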

Compound 3, concentration for 50% growth inhibition: > 100000 nM
Compound 3 ended at the assay's limit; the forecaster's own chance of this, stated with the estimate: 35%; middle value at least 1.6-fold (0.22 log units) away from the limit.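

In this assay compound 3 gives > 100000 nM, a limit of the assay and not a number. Replacing the saturated ring with an aromatic one at this carbon gives an at least 1.3-fold higher number from compound 2 to compound 3 (0.14 log units; that floor lies within the scatter), so phenyl and cyclohexyl are not told apart here, and the step between compound 1 and compound 3 cannot be read, as both ends are limits. Heptyl, cyclohexyl and phenyl on this saturated ring carbon next to the ring nitrogen therefore all leave the shared core a weak inhibitor of growth, and the readings now crowd the top of the range: the limit of > 100000 nM in this assay, at which 2 of the 3 values shown sit.

On these data alone, how far compound 1 and compound 3 lie past the limit remains unknown. Also open, as far as these compounds go, is whether an amine or a carboxylic acid on this carbon would bring growth inhibition into a measurable range.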